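Hydroxy on the cyclobutane ring: compound 1 to compound 4

The source may report more compounds than this note shows. Statements on the series, on what has been measured and on what is new or still open speak of the compounds shown alone.

Measured so far in an assay on HEK293 cells for agonist activity at Bile acid receptor (Homo sapiens); on this read-out higher numbers stand for an effect only at larger amounts of compound and lower numbers for an effect already at smaller amounts:
- compound 1 `O=C(O)c1cccc([C@H]2C[C@@H](c3ccc(OCc4c(-c5c(Cl)cccc5Cl)noc4C4CC4)cc3Cl)C2)c1` gives 92 nM
- compound 2 `CS(=O)(=O)NC(=O)c1ccc(C2CC2c2ccc(OCc3c(-c4c(Cl)cccc4Cl)noc3C3CC3)cc2Cl)cc1` gives 44 nM
- compound 3 `Clc1cc(OCc2c(-c3c(Cl)cccc3Cl)noc2C2CC2)ccc1C1CC1c1ccc(-c2nnn[nH]2)nc1` gives 111 nM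

Among these three, compound 1 stands second highest. Its nearest neighbour is compound 3, whose number lies within the usual scatter of that of compound 1, so no order between the two can be stated. Compound 2 gives the lowest number of the three, and its gap to compound 1 lies beyond the scatter.

Compound 4 `O=C(O)c1cccc([C@H]2C[C@](O)(c3ccc(OCc4c(-c5c(Cl)cccc5Cl)noc4C4CC4)cc3Cl)C2)c1` differs from compound 1 in one place: hydroxy in place of hydrogen on a saturated ring carbon, in words, hydroxy in place of hydrogen on a saturated ring carbon. Within the data shown here, no matched step of this kind exists among the measured compounds, so the size of the change is not known from this series.

The expectation is a small step from compound 1 to compound 4 towards a higher number in this assay, possibly not beyond the scatter, a 1.6-fold higher number from compound 1 to compound 4 (0.21 log units; within the scatter). Compound 4 is therefore estimated at 150 nM, with a range from 50 nM to 450 nM.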

Compound 4, half-maximal effective concentration: 25 nM
Compound 4: middle estimate off by 6.0-fold (0.78 log units), on the high side; measured number below the stated range.
By their numbers in this assay, from the lowest: compounds 4 and 2 (each within the scatter of the next); then compounds 1 and 3 (each within the scatter of the next).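

On the four-membered non-aromatic ring of carbon only, the saturated ring carbon two ring bonds from the ring atom that bears a 3-carboxyphenyl group accepts hydroxy in place of hydrogen. In this assay, among these compounds, this change gives a 3.7-fold lower number from compound 1 to compound 4 (0.57 log units; beyond the scatter) as the only matched step, so an effect is seen at smaller amounts of compound. The step shows that this carbon is a place where one added oxygen can shift the read-out beyond the scatter, and that the shift here runs towards the lower number. No measurement shown bears on the origin of this shift.

From the compounds shown here alone, whether a methoxy group, an amine or fluorine on the same carbon would shift the number in the same direction remains open. Also open, going by these compounds, is whether the hydroxy step would carry over to a core with another acidic end group, such as the tetrazole of compound 3.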